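A few compounds are considered here, and "the series" means these few. Any claim that something is new, unique, unknown or untested is made for them only; others in the source may bear on it.

Measured compounds:
Compound 1 `N#Cc1ccc(N2CCCc3c(-c4cccnc4)cccc32)cc1C(F)(F)F`: 12300 nM
Compound 2 `CCN(c1ccc(C#N)c(Cl)c1)c1cc(-c2cccs2)ccc1C`: 22000 nM
Compound 3 `N#Cc1ccc(N2CCc3cc(-c4cncnc4)ccc3C2)cc1C(F)(F)F`: "not determined" (no result reported)

The values come from a functional assay on CWR22R cells (Homo sapiens) for antiproliferative activity, read by CCK-8 assay, with a stated time of 6 days; on this read-out lower numbers stand for stronger inhibition and higher numbers for weaker inhibition. Compound 1 gives 12300 nM and compound 2 gives 22000 nM in this assay, while compound 3 has no result in this assay. Of the two numbers, compound 2 holds the higher one, but the number for compound 1 sits within the usual scatter of it, so the two compounds cannot be told apart on this evidence. Both numbers are large, so neither compound inhibits cell growth strongly.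

Compound 4 `CCN(c1ccc(C#N)c(Cl)c1)c1cc(-c2ccncc2)ccc1C` is built from compound 2 by one change: pyridin-4-yl in place of thiophen-2-yl on an aromatic carbon. The group that leaves and the group that enters are both small aromatic rings with a single hetero atom and one hydrogen-bond acceptor each, and the new ring stands on the same aromatic carbon, meta to a large group and para to a methyl group. For the measured compounds named here, no pair of measured compounds that differ in one place is available, so there is no measured step to lean on. With the change this small and the two groups so alike in what is counted, the expected step of a 1.4-fold lower number from compound 2 to compound 4 (0.14 log units; within the scatter) is small, with no clear direction beyond the usual scatter. Compound 4 is therefore estimated at 16000 nM, with a range from 5000 nM to 50000 nM.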

Compound 4, half-maximal inhibitory concentration: 1030 nM
Beside the measured number, compound 4's estimate is 16-fold (1.19 log units) above it; measured number below the stated range.
By their numbers in this assay, from the lowest: compound 4; then compounds 1 and 2 (each within the scatter of the next).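

In this assay, for the compounds shown here, this aromatic carbon, meta to a large group and para to a methyl group, proves sensitive to the ring it carries: pyridin-4-yl in place of thiophen-2-yl gives a 21-fold lower number from compound 2 to compound 4 (1.33 log units; beyond the scatter) and is the first step in this set to lie beyond the usual scatter. The two rings match in what is counted, each being a single aromatic ring with one hetero atom, one hydrogen-bond acceptor and no hydrogen-bond donors, so those counts alone do not tell which ring gives the lower number. Ring size and the hetero atom change together in this one step, and no measurement shown here explains its size.

As far as these compounds go, it remains open whether a phenyl ring or a pyridin-2-yl ring on the same carbon would give a number in this assay closer to that of compound 4 or to that of compound 2, which could help separate the effect of ring size from that of the hetero atom. From the compounds shown here alone, it is also open how a pyridin-4-yl ring carrying an added amine or a methoxy group would fare, and whether the same exchange would give a step of similar size on a different core.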